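A few compounds are considered here, and "the series" means these few. Any claim that something is new, unique, unknown or untested is made for them only; others in the source may bear on it.

Working notes on the series. Compound 1 `COc1ccc(CN(c2cc(OC)c(OC)c(OC)c2)S(=O)(=O)c2ccc(C)cc2)cc1` in a functional assay on PC-3 cells (Homo sapiens) for inhibition, read by MTT assay, with a stated time of 48 h (on this read-out lower numbers stand for stronger inhibition and higher numbers for weaker inhibition), gives 8220 nM. Compound 2 `COc1cc(N(Cc2nc3ccccc3[nH]2)S(=O)(=O)c2ccc(C)cc2)cc(OC)c1OC` in this assay gives 3340 nM. Among the compounds with values here, the one step seen so far is a 2.5-fold lower number from compound 1 to compound 2 (0.39 log units; beyond the scatter). Within the data shown here, compound 2 therefore stands with the lowest of the two numbers available, and the only neighbour, compound 1, sits at a higher number than compound 2 by that same step.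

Compound 3 `COc1cc(N(Cc2nc3ccccc3[nH]2)C(=O)c2ccc(Br)cc2)cc(OC)c1OC` differs from compound 2 in one place: (4-bromophenyl)carbonyl in place of (4-methylphenyl)sulfonyl on a nitrogen on an aromatic ring. Among the measured compounds shown here, no measured step touches this part of the molecule; the step from compound 1 to compound 2 concerns the group on the saturated chain carbon bound to the sulfonamide nitrogen, not the group on the nitrogen itself. No size or direction can be read from the two numbers available for this change. The working expectation is thus no step beyond the scatter in this assay, with wide uncertainty. For compound 3 the expected value in this assay is 3500 nM, with a range from 900 nM to 14000 nM. This estimate means an expected step of a 1.0-fold higher number from compound 2 to compound 3 (0.02 log units; within the scatter).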

Compound 3, half-maximal inhibitory concentration: 19900 nM
The estimate for compound 3 lay 5.7-fold (0.75 log units) below the measured number, and the stated range ends below it.
By their numbers in this assay, from the lowest: compound 2; then compound 1; then compound 3.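

Within the data shown here, the group on the nitrogen on an aromatic ring matters in this assay, which the earlier step at the saturated chain carbon could not show: (4-bromophenyl)carbonyl in place of (4-methylphenyl)sulfonyl gives a 6.0-fold higher number from compound 2 to compound 3 (0.78 log units; beyond the scatter) and is the first change to raise the number. The change replaces the sulfonyl with a carbonyl and the 4-methyl with a 4-bromo at once, so this single step cannot assign its size to either part. No measurement at hand accounts for the step.

The compounds shown leave open how (4-methylphenyl)carbonyl or (4-bromophenyl)sulfonyl would read at this nitrogen, which would separate the two parts of the change. They also leave open whether a simple acetyl, or a carboxylic acid or an amine on the phenyl ring of this group, would move the number in either direction.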